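This account rests on a few compounds, and the source may have more. Where it says the series, first, only, none or still open, it means among the compounds named here.

Measured in an ADME assay (liver) for metabolic stability, with Liver microsome (Homo sapiens) as the target, using microsomes and NADPH, with a stated time of 30 min, tested at 1 uM (on this read-out lower numbers stand for slow clearance and higher numbers for fast clearance), each result a limit:
compound 1 `Nc1ccc(S(=O)(=O)N2CCN(c3ncc(C(O)(C(F)(F)F)C(F)(F)F)cc3Br)CC2)cn1`: < 14 mL.min-1.g-1
compound 2 `COc1cc(C(O)(C(F)(F)F)C(F)(F)F)cnc1N1CCN(S(=O)(=O)c2ccc(N)nc2)CC1`: < 14 mL.min-1.g-1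
compound 3 `Nc1ccc(S(=O)(=O)N2CCN(c3ncc(C(O)(C(F)(F)F)C(F)(F)F)cc3C#CCO)CC2)cn1`: < 14 mL.min-1.g-1

Compound 3 gives < 14 mL.min-1.g-1, which is a limit and not a number. All three compounds share it: the limit of < 14 mL.min-1.g-1 in this assay, at which 3 of the 3 values shown sit. Compound 4 `CC(C)(O)C#Cc1cc(C(O)(C(F)(F)F)C(F)(F)F)cnc1N1CCN(S(=O)(=O)c2ccc(N)nc2)CC1` carries 1-hydroxy-1-methylethyl in place of hydroxymethyl on a triple-bonded carbon.

Going by the values given here, two measured steps bear on this change: a step that the two limits leave unreadable from compound 1 to compound 3 and a step that the two limits leave unreadable from compound 2 to compound 3. Neither gives a size. Bromo, methoxy and 3-hydroxyprop-1-yn-1-yl all reach the same limit, and no compound goes against this. From compound 3 and (the limit of < 14 mL.min-1.g-1 in this assay, at which 3 of the 3 values shown sit), no step beyond the scatter is expected in this assay, and no direction can be read. The expected step is a step that the limit leaves unreadable from compound 3 to compound 4. For compound 4 the estimate is 10 mL.min-1.g-1, with an expected range of 5 mL.min-1.g-1 to 20 mL.min-1.g-1.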

Compound 4, intrinsic clearance in microsomes: < 14 mL.min-1.g-1
Compound 4 gave a limit, no number; the forecaster's own chance of this, stated with the estimate: 75%; the middle value lies beyond the limit too.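

No step from compound 1, compound 2 or compound 3 to compound 4 can be read, as all four compounds give the same limit: the limit of < 14 mL.min-1.g-1 in this assay, at which 4 of the 4 values shown sit.

Going by these compounds, whether bromo, methoxy, 3-hydroxyprop-1-yn-1-yl and 3-hydroxy-3-methylbut-1-yn-1-yl differ in intrinsic clearance in microsomes stays open.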